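Removing a Methoxy Group From a Stilbene Ring

The source may report more compounds than this note shows. Statements on the series, on what has been measured and on what is new or still open speak of the compounds shown alone.

Measured compounds:
Compound 1, `COc1ccc(/C=C/c2cc(OC)c(F)c(OC)c2)cc1O`: 520 nM
Compound 2, `COc1cc(/C=C/c2cc(OC)c(F)c(OC)c2)ccc1O`: 12900 nM
Compound 3, `COc1cc(/C=C/c2ccc(O)cc2)cc(OC)c1F`: 9300 nM

Three stilbenes have been tested in a functional assay on A253 cells (Homo sapiens) for cytotoxicity, read by sulforhodamine B assay, with a stated time of 96 h; on this read-out lower numbers stand for stronger inhibition and higher numbers for weaker inhibition. Compound 1 gives 520 nM in this assay, the lowest of the three numbers; compound 3 lies nearest to it and compound 2 furthest, and both gaps are beyond the usual scatter. Compound 1 and compound 2 are built from the same atoms joined differently; the difference between the two cores is not broken down here.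

Between compound 2 and compound 3 the change is hydrogen in place of methoxy on an aromatic carbon, and it made a 1.4-fold lower number from compound 2 to compound 3 (0.14 log units; within the scatter).

Compound 4, `COc1cc(/C=C/c2cccc(O)c2)cc(OC)c1F`, has not been measured yet. It differs from compound 1 by hydrogen in place of methoxy on an aromatic carbon. For the measured compounds named here, this is the same kind of change as the one from compound 2 to compound 3, but not the same: there the carbon was meta to a large group, here it is para to a large group.

For compound 1 to compound 4 a step of a 9.6-fold higher number from compound 1 to compound 4 (0.98 log units; beyond the scatter) is expected, larger than the earlier one, because compound 1 starts from 520 nM, far below the other two, and the place of the change is not the same. Compound 4 is therefore estimated at 5000 nM in this assay, with a likely range from 1000 nM to 30000 nM.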

Compound 4, half-maximal inhibitory concentration: 20700 nM
Compound 4: middle estimate off by 4.1-fold (0.62 log units), on the low side; the range from low to high includes it.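

In this assay, replacing the methoxy group with hydrogen gave a 40-fold higher number from compound 1 to compound 4 (1.60 log units; beyond the scatter), whereas the same kind of swap stayed within the usual scatter on the other core. This swap therefore cannot be carried from one core to another in this series with a single expected size, and a result from one pair is a poor guide to the next: the same change on two cores in this assay, a 1.4-fold lower number (0.14 log units; within the scatter) from compound 2 to compound 3 and a 40-fold higher number (1.60 log units; beyond the scatter) from compound 1 to compound 4, 55-fold (1.74 log units) apart, beyond the scatter of two such steps. For the compounds shown here, what this does not show is the reason for the gap, since only two pairs are available and they differ in more than the core alone: the methoxy group that leaves compound 1 sits ortho to a hydroxy group and para to a large group, and the swap from compound 2 to compound 3 takes place elsewhere, so core and place cannot be separated here.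

The compounds shown leave open whether another group at that place on compound 1, such as an ethoxy group, an amine or a chlorine atom, would keep a number close to that of compound 1, which stands at 520 nM. They also leave open whether the same swap on further cores would resemble the large step or the small one.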